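Removing the chloro from compound 2's pyrazole

The source may report more compounds than this note shows. Statements on the series, on what has been measured and on what is new or still open speak of the compounds shown alone.

Compound 2 `C[C@@H]1CCCN1c1c(C#N)c2c(N)nc(Nc3cn(C)nc3Cl)nc2n1C` holds the lowest number of the two measured compounds in an assay on isolated protein for inhibition of Leucine-rich repeat serine/threonine-protein kinase 2 variant G2019S (Homo sapiens), read by TR-FRET and LanthaScreen, with stated times of 50 min and 30 min, in the presence of a further agent that is not named here (a lower number here means a stronger inhibitor, a higher number a weaker inhibitor), giving 21 nM, while compound 1 `Cc1c(Nc2nc(N)c3c(C#N)c(N4CCC[C@H]4C)n(C)c3n2)cnn1C` gives 43 nM. Within the data shown here, the one measured step, a 2.0-fold lower number from compound 1 to compound 2 (0.31 log units; beyond the scatter), exchanged one small group for another on the pyrazole. Compound 3 `C[C@@H]1CCCN1c1c(C#N)c2c(N)nc(Nc3cnn(C)c3)nc2n1C` differs from compound 2 by hydrogen in place of chloro on an aromatic carbon. Among the measured compounds shown here, no measured step removes that group outright, so the direction rests on that single modest step. Compound 3 is expected to sit near compound 2 or somewhat weaker, at a 1.9-fold higher number from compound 2 to compound 3 (0.28 log units; within the scatter). The estimate for compound 3 is 40 nM, within 15 nM to 110 nM.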

Compound 3, half-maximal inhibitory concentration: 5 nM
For compound 3 the middle estimate is 8.0-fold (0.90 log units) above the measured one; the whole stated range lies above it.
By their numbers in this assay, from the lowest: compound 3; then compound 2; then compound 1.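

In this assay, the chloro of compound 2 proves unnecessary for a low number: hydrogen in its place gives a 4.2-fold lower number from compound 2 to compound 3 (0.62 log units; beyond the scatter). Hydrogen in place of the methyl of compound 1 points the same way, with an 8.6-fold lower number from compound 1 to compound 3 (0.93 log units; beyond the scatter), so among these three compounds the pyrazole carrying neither group gives the lowest number. The evidence shown offers no explanation for either step. From the compounds shown here alone, whether a fluoro or a methoxy on that aromatic carbon would match compound 3 stays open. So does the effect of an ethyl in place of the pyrazole's remaining methyl.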